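Chain length and a new link in a small series

The source may hold more compounds than are shown below. What is called first, only, known or untested is meant among the compounds shown, and "the series" means these compounds.

Compound 1, `CCNc1ccc(/C=N/N=C(/N)S)nc1`: 3400 nM
Compound 2, `CCCNc1ccc(/C=N/N=C(/N)S)nc1`: 5100 nM
Compound 3, `CCCCNc1ccc(/C=N/N=C(/N)S)nc1`: 7800 nM

In a functional assay on L1210 cells (Mus musculus) for inhibition (a lower number here means a stronger inhibitor, a higher number a weaker inhibitor), compound 3 gives 7800 nM. It stands within the scatter of the propylamino compound and beyond the scatter of the ethylamino compound, as the measured steps show: a 1.5-fold higher number from compound 2 to compound 3 (0.18 log units; within the scatter) and a 2.3-fold higher number from compound 1 to compound 3 (0.36 log units; beyond the scatter). The remaining step is a 1.5-fold higher number from compound 1 to compound 2 (0.18 log units; within the scatter).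

Compound 4 (`NCc1ccc(/C=N/N=C(/N)S)nc1`) has not yet been measured. Its change is aminomethyl in place of butylamino on an aromatic carbon. All three measured steps only alter chain length on the amino group, so they bear on this change in part. The new group is shorter, which points to a lower number, on the scale of a 2.3-fold higher number from compound 1 to compound 3 (0.36 log units; beyond the scatter). However, no measured compound joins its nitrogen to the ring through carbon, so the uncertainty is wide.

The expected step is a 1.7-fold lower number from compound 3 to compound 4 (0.24 log units; within the scatter), and no change beyond the scatter is expected.

For compound 4 the estimated value is 4500 nM, with an expected range from 1500 nM to 13000 nM.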

Compound 4, half-maximal inhibitory concentration: 2100 nM
For compound 4 the middle estimate is 2.1-fold (0.33 log units) above the measured one, within the range that was stated.
By their numbers in this assay, from the lowest: compounds 4, 1, 2 and 3 (each within the scatter of the next, the first and the last beyond it).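

In this assay, aminomethyl in place of butylamino on this aromatic carbon gives a 3.7-fold lower number from compound 3 to compound 4 (0.57 log units; beyond the scatter), and aminomethyl in place of propylamino gives a 2.4-fold lower number from compound 2 to compound 4 (0.39 log units; beyond the scatter), so this position accepts a group that joins its nitrogen to the ring through carbon without any loss against these two chains. Against the ethylamino group the same kind of change gives a 1.6-fold lower number from compound 1 to compound 4 (0.21 log units; within the scatter), so compound 4 cannot be told apart from compound 1, and the new link shows no gain over the shortest chain shown. Nothing measured here accounts for these numbers.

Each of these changes alters the link to the ring and the size of the group together, so the effects of the two remain unseparated. From the compounds shown here alone, whether an aminoethyl chain or a methylamino group would follow compound 4 or the amino chains remains open.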